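A few compounds are considered here, and "the series" means these few. Any claim that something is new, unique, unknown or untested is made for them only; others in the source may bear on it.

In a functional assay on the whole organism (blood, strain Wistar-Okamoto) with Rattus norvegicus as the target, with a stated time of 5 days (a higher number here means that more compound is needed for the effect, a lower number that less compound is needed), the three measured compounds give the following numbers:
Compound 1 `N#CNC(=N)Nc1cccnc1` gives 50 mg/kg.
Compound 2 `CC(C)C/N=C(\NC#N)Nc1cccnc1` gives 20 mg/kg.
Compound 3 `CCCC(C)(C)/N=C(\NC#N)Nc1cccnc1` gives 1 mg/kg.

Compound 2 stands second highest of these three numbers. Its nearest neighbour is compound 1, whose number is higher and beyond the scatter; its furthest is compound 3, which needs much less compound, again beyond the scatter.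

Compound 4 `CCC(C)(CC)/N=C(\NC#N)Nc1cccnc1` has not yet been measured in this assay. It differs from compound 2 in one place: 1-ethyl-1-methylpropyl in place of isobutyl on a double-bonded nitrogen. For the measured compounds named here, only one measured step bears on this change, the one on the same double-bonded nitrogen in which 1,1-dimethylbutyl replaced isobutyl, giving a 20-fold lower number from compound 2 to compound 3 (1.30 log units; beyond the scatter). The 1-ethyl-1-methylpropyl group entering in compound 4 and the 1,1-dimethylbutyl group of compound 3 are groups of the same size and the same branching at the carbon joined to the nitrogen, so a step of like direction and like magnitude is expected in this assay for compound 4, namely a 13-fold lower number from compound 2 to compound 4 (1.12 log units; beyond the scatter). Whether the two groups behave identically cannot be told from the compounds in hand, so the range is kept wide. The estimate for compound 4 is 1.5 mg/kg, expected to fall between 0.5 mg/kg and 5 mg/kg.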

Compound 4, minimum effective dose: 0.5 mg/kg
Compound 4: middle estimate off by 3.0-fold (0.48 log units), on the high side; measured number inside the range.
By their numbers in this assay, from the lowest: compounds 4 and 3 (each within the scatter of the next); then compound 2; then compound 1.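

In this assay, 1-ethyl-1-methylpropyl in place of isobutyl on the double-bonded nitrogen gives a 40-fold lower number from compound 2 to compound 4 (1.60 log units; beyond the scatter) and so shows that a large step at this position is not confined to 1,1-dimethylbutyl, the only replacement for isobutyl seen before. Among the listed compounds, both larger groups now give a large step from the isobutyl compound, so the earlier result no longer rests on a single example. Exchanging 1,1-dimethylbutyl for 1-ethyl-1-methylpropyl gives a 2.0-fold lower number from compound 3 to compound 4 (0.30 log units; within the scatter) and therefore does not separate the two groups, which share the same count of heavy atoms but differ in how their carbons are arranged; no information is at hand on what lies behind these steps.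

The compounds shown do not tell whether the large steps follow from the greater size of the entering groups or from their particular branching, and an unbranched hexyl chain would bear directly on that question. They also leave open how a smaller tert-butyl group, a cyclohexyl ring or a group carrying a hydroxyl or an amine would behave on the same double-bonded nitrogen.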